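Para-Methoxy Substitution on the Triazole-Linked Phenyl Ring

This account rests on a few compounds, and the source may have more. Where it says the series, first, only, none or still open, it means among the compounds named here.

Measured so far:
Compound 1, `CC1(C)[C@H]2CC[C@]1(C)N(Cc1cn(-c3ccccc3Br)nn1)C(=O)C2`: 130 nM
Compound 2, `CC1(C)[C@H]2CC[C@]1(C)N(Cc1cn(-c3ccccc3)nn1)C(=O)C2`: 70 nM

Among the measured compounds shown here, the two compounds measured so far share one core and differ only on the phenyl ring attached to the triazole. In a functional assay on A549 cells (Homo sapiens) for inhibition, read by MTT assay, with a stated time of 24 h (on this read-out higher numbers stand for weaker inhibition and lower numbers for stronger inhibition), compound 1 gives 130 nM, while compound 2 gives 70 nM. The step of a 1.9-fold lower number from compound 1 to compound 2 (0.27 log units; within the scatter) is too small to be read as a real difference, so compound 2 cannot be called the stronger of the two; it simply has the lowest number of the two.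

Compound 3, `COc1ccc(-n2cc(CN3C(=O)C[C@@H]4CC[C@@]3(C)C4(C)C)nn2)cc1`, is the next compound to be measured. Relative to compound 2 the change is methoxy in place of hydrogen on an aromatic carbon. For the measured compounds named here, no measured step involves a methoxy group; the only step known, a 1.9-fold lower number from compound 1 to compound 2 (0.27 log units; within the scatter), concerns a different substituent and stayed within the scatter. On that basis compound 3 is expected to show a step of a 1.1-fold higher number from compound 2 to compound 3 (0.06 log units; within the scatter), that is, no change beyond the scatter. Compound 3 is therefore estimated at 80 nM, within the range 35 nM to 180 nM.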

Compound 3, half-maximal inhibitory concentration: 50 nM
For compound 3 the middle estimate is 1.6-fold (0.20 log units) above the measured one; measured number inside the range.
By their numbers in this assay, from the lowest: compounds 3, 2 and 1 (each within the scatter of the next, the first and the last beyond it).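

Methoxy in place of hydrogen, on an aromatic carbon para to a large group, is the first added group seen at this place, and in this assay it gives a 1.4-fold lower number from compound 2 to compound 3 (0.15 log units; within the scatter), so this addition leaves the number within the scatter. Among the compounds shown here, the first step beyond the scatter also appears here, a modest one: a 2.6-fold lower number from compound 1 to compound 3 (0.41 log units; beyond the scatter), but it swaps 2-bromophenyl for 4-methoxyphenyl as a whole and cannot show whether losing bromo or gaining methoxy accounts for it. No available evidence explains either step.

Going by these compounds, whether an amine, a carboxylic acid or a longer chain such as ethoxy at this same place would leave the number within the scatter remains open. So does whether methoxy would read the same on another carbon of this ring.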